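Swapping the methyl for nitro on the benzamide ring

The source may hold more compounds than are shown below. What is called first, only, known or untested is meant among the compounds shown, and "the series" means these compounds.

Three compounds share one core and differ only in the aryl group on the carbonyl carbon. In an assay (strain Wistar) for displacement of a labelled ligand from adenosine receptor A1 (Rattus norvegicus), read by scintillation counting (a higher number here means a weaker inhibitor, a lower number a stronger inhibitor), compound 1 `CCOc1ccccc1C(=O)Nc1nc(-c2ccccc2)nc2c1nnn2Cc1ccccc1` gives 1850 nM, compound 2 `COc1ccc(Cl)cc1C(=O)Nc1nc(-c2ccccc2)nc2c1nnn2Cc1ccccc1` gives 7150 nM, and compound 3 `Cc1ccc(C(=O)Nc2nc(-c3ccccc3)nc3c2nnn3Cc2ccccc2)cc1` gives 709 nM, the lowest of the three. The measured steps were a 2.6-fold lower number from compound 1 to compound 3 (0.42 log units; beyond the scatter) and a 10-fold lower number from compound 2 to compound 3 (1.00 log units; beyond the scatter). Compound 4 `O=C(Nc1nc(-c2ccccc2)nc2c1nnn2Cc1ccccc1)c1ccc([N+](=O)[O-])cc1` differs from compound 3 by nitro in place of methyl on an aromatic carbon. Among the measured compounds shown here, no measured step touches this exact change, so the expectation rests only on the moderate spread across compounds 1, 2 and 3. Compound 4 is expected to give 1200 nM in this assay, within 300 nM to 5000 nM, a step of a 1.7-fold higher number from compound 3 to compound 4 (0.23 log units; within the scatter) expected from compound 3 to compound 4.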

Compound 4, inhibition constant: 24 nM
For compound 4 the middle estimate is 50-fold (1.70 log units) above the measured one; the measured number lies below the stated range.
By their numbers in this assay, from the lowest: compound 4; then compound 3; then compound 1; then compound 2.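

Nitro in place of methyl at this position gives a 30-fold lower number from compound 3 to compound 4 (1.47 log units; beyond the scatter) and that step exceeds every step among the earlier compounds, so this place on the ring can move the number far more than they suggested. The 4-nitrophenyl group also shows a 77-fold lower number from compound 1 to compound 4 (1.89 log units; beyond the scatter) and a 300-fold lower number from compound 2 to compound 4 (2.47 log units; beyond the scatter) and so compound 4 stands lowest of the four, beyond the scatter against each. No evidence at hand accounts for the size of these steps.

The compounds shown leave open whether this drop is particular to nitro. A nitrile, an amine or a carboxylic acid at the same place would help settle that.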